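This account rests on a few compounds, and the source may have more. Where it says the series, first, only, none or still open, it means among the compounds named here.

Working notes on the series. Of the compounds shown here, two have numbers so far in an assay on HEK293 cells for positive allosteric modulation of metabotropic glutamate receptor 3 (Rattus norvegicus), read by thallium flux, with a stated time of 2.5 min; a lower number here means a smaller maximal response, a higher number a larger maximal response. Compound 1, `COC(=O)c1ccc(OCCCCOc2ccc(C(=O)CC3CCCC3)c(O)c2C)cc1`, gives 22% in this assay. Compound 2, `CCCC(=O)c1ccc(OCCCCOc2ccc(C(=O)O)cc2C)c(C)c1O`, gives 40.5% in this assay, the higher of the two numbers, standing a gap beyond the usual scatter above compound 1. For the measured compounds named here, no single-point step between these two measured compounds is defined, so their two values are noted only as they stand.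

Compound 3, `Cc1cc(C(=O)O)ccc1OCCCCOc1ccc(C(=O)CC2CCCC2)c(O)c1C`, has not yet been measured. It differs from compound 2 in one place: cyclopentyl in place of ethyl on a saturated chain carbon bound to a carbonyl carbon. Going by the values given here, the same cyclopentylmethylcarbonyl grouping is present in compound 1, which sits at the lower of the two known numbers, though compound 1 also differs from compound 3 elsewhere. A downward step in this assay is therefore expected, moderate in size, by a number 12.5 percentage points lower from compound 2 to compound 3 (beyond the scatter). Compound 3 is estimated at 28%, with a range from 15% to 42%.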

Compound 3, largest response reached (reported as percent of maximum), in percent of the reference or control that the assay uses: 28.4%
The estimate for compound 3 lay 0.4 percentage points below the measured number; low and high end bracket the measured number.
By their numbers in this assay, from the lowest: compounds 1 and 3 (each within the scatter of the next); then compound 2.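

In this assay, cyclopentyl in place of ethyl on a saturated chain carbon bound to a carbonyl carbon gives a number 12.1 percentage points lower from compound 2 to compound 3 (beyond the scatter) as a single-place reading, so the maximal response shifts at this position while the rest of the molecule stays the same. With the (cyclopentylmethyl)carbonyl grouping kept, 4-carboxy-2-methylphenyl in place of 4-(methoxycarbonyl)phenyl on an oxygen on a saturated carbon gives a number 6.4 percentage points higher from compound 1 to compound 3 (within the scatter) and does not separate the two compounds in this read-out. No measurement at hand bears on the reason for either step.

The compounds shown leave open whether the step at the chain follows the ring or the added carbons, and a pentyl chain or a cyclopropyl ring at the same place would separate the two. Also open, as far as these compounds go, is how an amide in place of the carboxylic acid would read.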